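A few compounds are considered here, and "the series" means these few. Any claim that something is new, unique, unknown or untested is made for them only; others in the source may bear on it.

Compound 1 `N#Cc1ccc(Nc2nccc(Oc3ccc(OCc4ccccc4)cc3)n2)cc1`, compound 2 `COCCc1ccc(Oc2ccnc(Nc3ccc(C#N)cc3)n2)cc1` and compound 3 `Cc1cnc(Nc2ccc(C#N)cc2)nc1Oc1ccc(OCc2ccccc2)cc1` share one core, and compound 4 `COCCc1ccc(Oc2nc(Nc3ccc(C#N)cc3)ncc2C)cc1` is the fourth member of the set. In an ADME assay on MT4 cells (Homo sapiens) for cytotoxicity, read by MTT assay, with a stated time of 5 days (on this read-out higher numbers stand for lower toxicity in this test and lower numbers for higher toxicity in this test), compound 1 gives only a limit, > 316000 nM, because it sits at the limit of > 316000 nM in this assay, at which 1 of the 3 values shown sits. In this assay compound 2 gives 93300 nM and compound 3 gives 170000 nM. The change 2-methoxyethyl in place of benzyloxy on an aromatic carbon made an at least 3.3-fold lower number from compound 1 to compound 2 (0.52 log units; beyond the scatter). The change methyl in place of hydrogen on an aromatic carbon made an at least 1.8-fold lower number from compound 1 to compound 3 (0.26 log units; that floor lies within the scatter), and this is also how the core of compound 3 differs from the core of compound 1. Compound 4 carries the same change as compound 2, (2-methoxyethyl in place of benzyloxy on an aromatic carbon), and is expected to show a 2.8-fold lower number from compound 3 to compound 4 (0.45 log units; beyond the scatter), on the strength of what compound 2 showed in an at least 3.3-fold lower number from compound 1 to compound 2 (0.52 log units; beyond the scatter). Compound 4 is therefore expected to give about 60000 nM in this assay.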

Compound 4, half-maximal cytotoxic concentration: > 346000 nM
Compound 4 ended at the assay's limit; the forecaster's own chance of this, stated with the estimate: 10%; at least 5.7-fold (0.76 log units) between middle value and limit.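

In this assay, 2-methoxyethyl in place of benzyloxy on the methyl-bearing core gave an at least 2.0-fold higher number from compound 3 to compound 4 (0.30 log units; that floor lies within the scatter), and this step differs from the one on the core of compound 1: the same change on two cores in this assay, an at least 3.3-fold lower number (0.52 log units; beyond the scatter) from compound 1 to compound 2 and an at least 2.0-fold higher number (0.30 log units; that floor lies within the scatter) from compound 3 to compound 4, at least 6.8-fold (0.83 log units) apart, beyond the scatter of two such steps. Methyl in place of hydrogen, with 2-methoxyethyl present, gave an at least 3.7-fold higher number from compound 2 to compound 4 (0.56 log units; beyond the scatter), and this step also differs from the earlier one: the same change on two cores in this assay, an at least 1.8-fold lower number (0.26 log units; that floor lies within the scatter) from compound 1 to compound 3 and an at least 3.7-fold higher number (0.56 log units; beyond the scatter) from compound 2 to compound 4, at least 6.8-fold (0.83 log units) apart, beyond the scatter of two such steps. Neither change therefore carries over as a fixed step between these cores, but compound 1 and compound 4 give limits rather than numbers, so the true sizes of the steps stay unknown, and the data do not show why they differ.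

Going by these compounds, whether an amine or a longer chain in place of 2-methoxyethyl would behave like compound 2 or like compound 4 stays open.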